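Bromo in place of methyl on a shared core

The source may hold more compounds than are shown below. What is called first, only, known or untested is meant among the compounds shown, and "the series" means these compounds.

Of the compounds shown here, three on a shared core have been measured in a functional assay on the whole organism with Mus musculus as the target; on this read-out lower numbers stand for an effect already at smaller amounts and higher numbers for an effect only at larger amounts of compound. Compound 1, `Cc1ccccc1Oc1ccc2nncn2n1`, gives 54.8 mg/kg in this assay. Compound 3, `COc1ccccc1Oc1ccc2nncn2n1`, carries a methoxy in place of the methyl and reaches only a limit of the assay, > 100 mg/kg. The step of an at least 1.8-fold higher number from compound 1 to compound 3 (0.26 log units; that floor lies within the scatter) is therefore only a floor, and that floor lies within the scatter. Compound 2, `Cc1ccc(Oc2ccc3nncn3n2)cc1`, likewise reaches only a limit of the assay, > 100 mg/kg. Compound 2 thus stands at the limit of > 100 mg/kg in this assay, at which 2 of the 3 values shown sit, so its place among the three is known only as this limit.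

Compound 4, `Brc1ccc(Oc2ccc3nncn3n2)cc1`, differs from compound 2 by bromo in place of methyl on an aromatic carbon. Among the measured compounds shown here, no measured step exchanges methyl for bromo. For the measured compounds named here, the single measured step, from compound 1 to compound 3, replaces methyl by methoxy and is no larger than a floor within the scatter. Nothing measured points to a step beyond the scatter in either direction for compound 4, and compound 2 itself offers only a limit as the starting point. Compound 4 is therefore expected to give an estimated 120 mg/kg in this assay, between 50 mg/kg and 300 mg/kg. The step that the limit leaves unreadable from compound 2 to compound 4 that this estimate means is expected to be small, and it is expected that this assay may again report only a limit.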

Compound 4, dose for half-maximal effect: 49.1 mg/kg
Estimate against measurement, compound 4: 2.4-fold (0.39 log units) above; measured number below the stated range.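

Among the compounds shown here, with bromo in place of methyl on an aromatic carbon, para to a large group, this assay returns a number at this position for the first time, whereas compound 2, with methyl there, gave only a limit. The change reads as an at least 2.0-fold lower number from compound 2 to compound 4 (0.30 log units; that floor lies within the scatter), so the true step may be larger, but what can be read of it is only a floor and does not go beyond the usual spread of repeat measurements. The bromo compound therefore shows that this position can carry a measurable effect, while the size of the change from methyl remains unknown: the limit of > 100 mg/kg in this assay, at which 2 of the 4 values shown sit.

The compounds shown leave open how other groups at this same place would read, such as chloro, an amine or a carboxylic acid, as only methyl and bromo stand there. They also leave open whether bromo would give a similar reading at the place where compound 1 carries its methyl, and whether a longer chain would be tolerated at either place.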